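This account rests on a few compounds, and the source may have more. Where it says the series, first, only, none or still open, it means among the compounds named here.

Compound 1 `COc1cc(C)cc(-c2c(-c3ccnc(-c4ccc(C(C)=O)cc4)c3)cnn2CC#N)c1` was examined in a functional assay on HT-29 cells (Homo sapiens) for cytotoxicity, read by sulforhodamine B assay, with a stated time of 48 h, tested at 0.01 uM (on this read-out lower numbers stand for a stronger effect and higher numbers for a weaker effect at the one concentration tested), and, at the single concentration used there, compound 1 gives 96%. A second compound, compound 2 `Cc1cc(O)cc(-c2nn(CC#N)cc2-c2ccnc(-c3ccc(Oc4ccccc4)cc3)c2)c1`, was run the same way; in this assay compound 2 gives 104%. Of the two numbers compound 1 has the lower one, yet the two values lie within the scatter of each other, so neither compound can be set apart from the other on this read-out.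

Compound 3 `COc1cc(C)cc(-c2c(-c3ccnc(-c4ccc(N(C)C)cc4)c3)cnn2CC#N)c1` has not yet been measured. It differs from compound 1 in a single place: dimethylamino in place of acetyl on an aromatic carbon. The dimethylamino group enters on an aromatic carbon of a six-membered aromatic ring of carbon only, para to a large group, at the spot the acetyl group leaves. No measured step of this kind exists among the compounds shown, so the expectation rests only on the two values above and on the small size of the change. The step expected in this assay is a number 1 percentage points higher from compound 1 to compound 3 (within the scatter), that is, nothing beyond the scatter. Compound 3 is therefore estimated to give 97% in this assay, with a range from 84% to 110%.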

Compound 3, a percentage reported as activity, at one concentration (the size of the read-out at that concentration, not a potency): 26%
For compound 3 the middle estimate is 71 percentage points above the measured one; measured number below the stated range.
By their numbers in this assay, from the lowest: compound 3; then compounds 1 and 2 (each within the scatter of the next).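

In this assay, putting dimethylamino in place of acetyl on an aromatic carbon of a six-membered aromatic ring of carbon only, para to a large group, gives a number 70 percentage points lower from compound 1 to compound 3 (beyond the scatter), the first one-place step available in this series and a large one. The change leaves the count of heavy atoms, hydrogen-bond donors and hydrogen-bond acceptors as it was, and the one counted difference is the double bond outside aromatic rings that goes with the acetyl group, so this position responds strongly to a swap that these counts barely register. No measurement among the data at hand explains the size of this step.

The compounds shown leave open whether the gain belongs to dimethylamino itself or would also follow with another group at this spot, such as a primary amine, a methylamino group, a pyrrolidine ring or a methoxy group. They also leave open whether the same swap would give a step of similar size on a core carrying a hydroxyl group in place of the methoxy group of compound 1.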